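Fluoro to hydrogen on compound 2

The compounds below may be only part of what the source reports. "The series", "measured", "known", "first", "only" and "open" are said of these compounds alone.

Going by the values given here, compound 2 (`Cn1cc(-c2ccc(C(F)(F)F)cc2)c2cc(F)c(C(=O)NS(C)(=O)=O)cc21`) holds the only number so far: in an ADME assay on Caco-2 cells (Homo sapiens) for permeability, in the apical to basolateral direction (a lower number here means that the compound crosses the layer more slowly, a higher number that the compound crosses the layer faster), compound 2 gives 20 nm/s. Compound 1 (`Cn1cc(-c2ccc(C(F)(F)F)cc2)c2ccc(C(=O)NS(=O)(=O)C3CC3)cc21`) offers no comparison, as the entry for compound 1 reads "not determined" (no result reported). Compound 3 (`Cn1cc(-c2ccc(C(F)(F)F)cc2)c2ccc(C(=O)NS(C)(=O)=O)cc21`) differs from compound 2 by a single change, hydrogen in place of fluoro on an aromatic carbon. Among the compounds with values here, no measured pair shows this change or any other single change, so the series gives no direct guide to its size. For a swap this small, no shift beyond the scatter in this assay is expected, in either direction. The expected result is no change at the digits printed from compound 2 to compound 3 (within the scatter), which stays within the scatter. The estimate therefore stays anchored on compound 2 at 20 nm/s. For compound 3 the estimated value is 20 nm/s, with an expected range of 8 nm/s to 50 nm/s.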

Compound 3, apparent permeability: < 15 nm/s
Compound 3 was reported as a limit; the forecaster's own chance of this, stated with the estimate: 10%; middle value at least 1.3-fold (0.12 log units) away from the limit.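

In this assay compound 3 gives < 15 nm/s, which is a limit of the assay and not a number. Hydrogen in place of fluoro on an aromatic carbon, ortho to a (methylsulfonyl)carbamoyl group, now has a first reading at this position, an at least 1.3-fold lower number from compound 2 to compound 3 (0.12 log units; that floor lies within the scatter), so the series points to a lower number, although the floor of that step does not clear the scatter. The full size of the step stays open because the reading for compound 3 ends at a limit: the limit of < 15 nm/s in this assay, at which 1 of the 3 values shown sits.

The compounds shown leave open whether chloro or methoxy on the same aromatic carbon would read apart from fluoro in this assay. They also leave open how a carboxylic acid in place of the (methylsulfonyl)carbamoyl group would read on the shared core.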